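This account rests on a few compounds, and the source may have more. Where it says the series, first, only, none or still open, it means among the compounds named here.

Measured compounds:
- compound 1, `Cc1ccc(-c2cc(/N=C/N(C)C)n(-c3cccc(Cl)c3)n2)cc1`, > 100000 nM in a functional assay on Jurkat cells (Homo sapiens) for inhibition, read by MTT assay, with a stated time of 72 h; a lower number here means a stronger inhibitor of growth, a higher number a weaker inhibitor of growth
- compound 2, `Cc1ccc(-c2cc(/N=C/N(C)C)n(-c3ccc(Br)cc3)n2)cc1`, > 100000 nM in this assay
- compound 3, `Cc1ccc(-c2nn(-c3cccc(Cl)c3)c(N)c2C=O)cc1`, 86300 nM in this assay

Compound 1 sits at a limit of this assay and gives no number. Compound 2 likewise sits at a limit of this assay and gives no number. For the measured compounds named here, compound 3 is the only compound of the three that gives a number in this assay, and it lies close to the limit at which the other two stand, (the limit of > 100000 nM in this assay, at which 2 of the 3 values shown sit).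

The change from compound 1 to compound 2 is 4-bromophenyl in place of 3-chlorophenyl on an aromatic nitrogen. Both values are limits, so a step that the two limits leave unreadable from compound 1 to compound 2. How the core of compound 1 differs from the core of compound 3 is not broken down here.

Compound 4, `Cc1ccc(-c2nn(-c3ccc(Br)cc3)c(N)c2C=O)cc1`, is not yet measured. It differs from compound 3 by 4-bromophenyl in place of 3-chlorophenyl on an aromatic nitrogen. This is the same kind of change as that from compound 1 to compound 2, but not the same: around the place in compound 3 the aromatic nitrogen is next to the ring atom that bears an amino group and two ring bonds from the ring atom that bears a formyl group, whereas in compound 1 it is next to the ring atom that bears a group of 5 heavy atoms.

The step from compound 3 to compound 4 is expected to be a 1.0-fold higher number from compound 3 to compound 4 (0.02 log units; within the scatter), a small one, resting on compound 3 at 86300 nM and on the first pair, where the step stays unreadable as a step that the two limits leave unreadable from compound 1 to compound 2. Compound 4 is estimated at 90000 nM in this assay, between 30000 nM and 300000 nM, with a fair chance that only a limit is reported.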

Compound 4, concentration for 50% growth inhibition: 34400 nM
Compound 4: middle estimate off by 2.6-fold (0.42 log units), on the high side; the range from low to high includes it.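

In this assay, putting 4-bromophenyl in place of 3-chlorophenyl on the aromatic nitrogen of the core that bears the amino and formyl groups gives a 2.5-fold lower number from compound 3 to compound 4 (0.40 log units; beyond the scatter), and compound 4 stands at 34400 nM. From the compounds shown here alone, the same change on the core of compound 1 cannot be read, since compound 1 and compound 2 both give limits and not numbers: the limit of > 100000 nM in this assay, at which 2 of the 4 values shown sit. The result therefore shows that this change moves the number on one core only, and it shows neither agreement nor disagreement with the other core, so whether the change carries from one core to the other remains untested; nor does this one pair separate the exchange of chlorine for bromine from the different placing of the halogen on the phenyl ring.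

Going by these compounds, what a 4-chlorophenyl or a 3-bromophenyl group would give on the core of compound 3 stays open, and either would help to tell those two parts of the change apart. Also open, on these data alone, is what would follow if the formyl group gave way to a carboxylic acid, or the amino group to a longer amine chain.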